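Stripping the Pyridin-2-yl Ring: Expectation for Compound 3

The compounds below may be only part of what the source reports. "The series", "measured", "known", "first", "only" and "open" are said of these compounds alone.

Of the compounds shown here, two with a shared core have been tested in a functional assay on the whole organism (strain Sprague-Dawley) for inhibition, with Rattus norvegicus as the target, read by paw edema, with a stated time of 180 min, at a dose of 30 mg/kg by the oral route; on this read-out lower numbers stand for a weaker effect and higher numbers for a stronger effect at the one dose given. Compound 1 `COc1ccnc(CNc2ccc3c(c2)nc(C)n3C[C@@H](O)[C@H]2O[C@H](O)[C@@H](O)[C@H]2O)c1OC` gives 72%, and compound 2 `COc1c(C)cnc(CNc2ccc3c(c2)nc(C)n3C[C@@H](O)[C@H]2O[C@H](O)[C@@H](O)[C@H]2O)c1C` gives 56%. Among the measured compounds shown here, the single measured step, a number 16 percentage points lower from compound 1 to compound 2 (beyond the scatter), shows that exchanging the groups carried on the pyridin-2-yl ring shifts the read-out modestly. Compound 2 thus stands at the lower of the two numbers, with compound 1 above it beyond the scatter.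

Compound 3 `Cc1nc2cc(NCc3ccccn3)ccc2n1C[C@@H](O)[C@H]1O[C@H](O)[C@@H](O)[C@H]1O` has not yet been measured. It differs from compound 2 by pyridin-2-yl in place of 4-methoxy-3,5-dimethylpyridin-2-yl on a saturated chain carbon bound to a nitrogen on an aromatic ring. For the measured compounds named here, the only step that bears on this change is a number 16 percentage points lower from compound 1 to compound 2 (beyond the scatter), as it also concerns the groups on the pyridin-2-yl ring, and it was modest. A step of similar size in this assay is expected, most likely downward, a number 8 percentage points lower from compound 2 to compound 3 (within the scatter), though the data cannot rule out no change beyond the scatter. Compound 3 is therefore estimated at 48%, within 28% to 68%.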

Compound 3, a percentage reported as inhibition, in the whole organism at one dose (the size of the read-out at that dose, not a potency): 52%
For compound 3 the middle estimate is 4 percentage points below the measured one; low and high end bracket the measured number.
By their numbers in this assay, from the lowest: compounds 3 and 2 (each within the scatter of the next); then compound 1.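

In this assay, stripping the ring down to plain pyridin-2-yl gives a number 4 percentage points lower from compound 2 to compound 3 (within the scatter), so at this place on the chain the methoxy and two methyl groups of 4-methoxy-3,5-dimethylpyridin-2-yl make no difference that can be told from scatter. The same plain ring set against 3,4-dimethoxypyridin-2-yl gives a number 20 percentage points lower from compound 1 to compound 3 (beyond the scatter), which leaves compound 1 as the only one of the three standing apart, with a bare ring and a ring carrying three groups reading alike. No measurement here offers an explanation for this pattern.

Still open, on these data alone, is whether a single methoxy group, as in 4-methoxypyridin-2-yl, would be enough or both methoxy groups of compound 1 are needed. Also open, as far as these compounds go, is how a phenyl ring in place of the pyridin-2-yl ring would read.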